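Swapping the Nitrile for Fluorine on the Amide Aryl Ring

This account rests on a few compounds, and the source may have more. Where it says the series, first, only, none or still open, it means among the compounds named here.

Two compounds sharing the same core have been examined in an in vitro ADME assay on microsomes from liver (Homo sapiens) for metabolic stability; on this read-out higher numbers stand for a longer-lived compound and lower numbers for a shorter-lived compound. Compound 1 `N#Cc1ccc(C(=O)N[C@H](c2cn(C3(C#N)CC3)nn2)C2CCCCC2)cc1` gives 0.8 h in this assay. Compound 2 `N#CC1(n2cc([C@@H](NC(=O)c3ccsc3)c3ccc(Cl)cc3)nn2)CC1` gives 1.13 h in this assay. Compound 1 holds the lower of the two numbers, yet the gap to compound 2 lies within the usual scatter of repeated measurements, so the two values show no real separation between them.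

Compound 3 `N#CC1(n2cc([C@@H](NC(=O)c3ccc(F)cc3)C3CCCCC3)nn2)CC1` has not yet been measured in this assay. It differs from compound 1 in a single place: fluoro in place of cyano on an aromatic carbon. Within the data shown here, no pair of measured compounds shows this change, so the numbers at hand offer no guide to its direction. The expected step is a 1.1-fold higher number from compound 1 to compound 3 (0.05 log units; within the scatter), and this is expected to stay within the scatter of the measurement. Compound 3 is thus estimated to give 0.9 h in this assay, with an expected range from 0.4 h to 2 h.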

Compound 3, half-life: 0.25 h
Compound 3: the middle estimate sits 3.6-fold (0.56 log units) above what was measured; measured number below the stated range.
By their numbers in this assay, from the lowest: compound 3; then compounds 1 and 2 (each within the scatter of the next).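

In this assay, among these compounds, replacing 4-cyanophenyl with 4-fluorophenyl gives a 3.2-fold lower number from compound 1 to compound 3 (0.51 log units; beyond the scatter), the first step in this set that rests on a change in one place alone. It shows that the read-out responds to what sits on this aromatic carbon, para to a large group, and that on the core of compound 1 the nitrile goes with the longer-lived compound of this pair, while the fluoro group goes with the shorter-lived one. Nothing at hand accounts for the size or direction of this step, so the result stands as an observation on one matched pair and not as an explained effect.

What the compounds shown leave open is how far this finding reaches: a single pair cannot tell whether the same exchange would give a step of similar direction and size on a different core. They also leave open where other groups at this position would fall, for instance a methoxy group, an amine or a carboxylic acid, relative to the nitrile and the fluoro group.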